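The compounds below may be only part of what the source reports. "The series", "measured", "known", "first", "only" and "open" are said of these compounds alone.

Compound 1 `CCn1cc(-c2ccc(F)cc2)c(=O)c2cc(F)c(N3CCNCC3)cc21` and compound 2 `CCn1cc(-c2ccc(Cl)cc2)c(=O)c2cc(F)c(N3CCNCC3)cc21` are built on the same core and differ in one place only. In a functional assay on BGC-823 cells (Homo sapiens) for antiproliferative activity, read by MTT assay, with a stated time of 48 h (on this read-out lower numbers stand for stronger inhibition and higher numbers for weaker inhibition), compound 1 gives 69600 nM. In the same assay compound 2 gives 14600 nM. The change between them is chloro in place of fluoro on an aromatic carbon, and it produced a 4.8-fold lower number from compound 1 to compound 2 (0.68 log units; beyond the scatter).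

Compound 3 `O=c1c(-c2cccc(F)c2)cn(C2CC2)c2cc(N3CCNCC3)c(F)cc12` stands on another core; the difference between the two cores is not broken down here. In this assay compound 3 gives 12000 nM, a number within the usual scatter of that of compound 2, so the two cannot be told apart, while it lies well beyond the scatter from the number of compound 1.

Compound 4 `O=c1c(-c2cccc(Cl)c2)cn(C2CC2)c2cc(N3CCNCC3)c(F)cc12` has not yet been measured. It differs from compound 3 by chloro in place of fluoro on an aromatic carbon. Going by the values given here, this is the same kind of change as the one from compound 1 to compound 2, but not the same change: in compound 1 the fluoro sits para to a large group, in compound 3 it sits meta to a large group, and the cores differ as well.

Because the earlier change of this kind gave a 4.8-fold lower number from compound 1 to compound 2 (0.68 log units; beyond the scatter), a step in the same direction is expected here, though the different placement and core make its size less certain; the expected step is a 2.5-fold lower number from compound 3 to compound 4 (0.40 log units; beyond the scatter). Compound 4 is therefore expected to give 4800 nM, with a likely range from 2000 nM to 12000 nM.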

Compound 4, half-maximal inhibitory concentration in the BGC-823 assay: 610 nM
The estimate for compound 4 lay 7.9-fold (0.90 log units) above the measured number, outside the stated range (below it).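

In the BGC-823 assay, chloro in place of fluoro on the aromatic carbon meta to a large group gives a 20-fold lower number from compound 3 to compound 4 (1.29 log units; beyond the scatter), which is a large step. The direction of the change carries over from one core to the other, but its size does not: the same change on two cores in the BGC-823 assay, a 4.8-fold lower number (0.68 log units; beyond the scatter) from compound 1 to compound 2 and a 20-fold lower number (1.29 log units; beyond the scatter) from compound 3 to compound 4, 4.1-fold (0.62 log units) apart, beyond the scatter of two such steps This does not show what sets the two steps apart, since the two pairs differ both in the core and in where the halogen sits, and two pairs cannot separate these differences or give a rule for other cores in the series.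

In a physicochemical assay for solubility, at pH 7.9 (a higher number here means a more soluble compound, a lower number a less soluble compound), compound 3 gives > 400000 nM, which is a limit of the assay and not a number. In the physicochemical assay compound 4 gives > 400000 nM, which is also a limit of the assay and not a number. In the physicochemical assay the step from compound 3 to compound 4 cannot be read, and nothing can be said about any difference in solubility, as both compounds sit at a limit of the assay rather than at a number: the limit of > 400000 nM in the physicochemical assay, at which 2 of the 2 values shown sit. The compounds shown leave open whether the larger step belongs to the core of compound 3 or to the place of the chloro, and whether a bromo or a methoxy group on the same aromatic carbon would lower the number further.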